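From Diethylamino to Dibutylamino on the Shared Core

A few compounds are considered here, and "the series" means these few. Any claim that something is new, unique, unknown or untested is made for them only; others in the source may bear on it.

In a functional assay on DU-145 cells (Homo sapiens) for antiproliferative activity, read by WST assay, with a stated time of 3 days (a lower number here means a stronger inhibitor, a higher number a weaker inhibitor), compound 1 `CCCCCCCOc1c(-c2cc(OC)c(OC)c(OC)c2)oc2ccccc2c1=O` reaches only a limit of the assay, > 50000 nM. Compound 2 `CCCC(C)Oc1c(-c2cc(OC)c(OC)c(OC)c2)oc2ccccc2c1=O` likewise reaches only a limit, > 50000 nM. Compound 3 `CCN(CC)CCCCOc1c(-c2cc(OC)c(OC)c(OC)c2)oc2ccccc2c1=O` alone gives a number, 13300 nM. The steps to it are an at least 3.7-fold lower number from compound 1 to compound 3 (0.57 log units; beyond the scatter) and an at least 3.7-fold lower number from compound 2 to compound 3 (0.57 log units; beyond the scatter). Compound 4 `CCCCN(CCCC)CCCOc1c(-c2cc(OC)c(OC)c(OC)c2)oc2ccccc2c1=O` differs from it by dibutylamino in place of (diethylamino)methyl on a saturated chain carbon, three bonds along the chain from an oxygen on an aromatic ring. Neither measured step exchanges one amino group for another, so they give no direct size for this change. Compound 4 keeps an amino group, however, which favours a reading near that of compound 3 at 13300 nM. The expected step is a 1.3-fold lower number from compound 3 to compound 4 (0.12 log units; within the scatter), with nothing beyond the scatter anticipated. For compound 4 the estimated value is 10000 nM, within an expected range of 3000 nM to 40000 nM.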

Compound 4, half-maximal inhibitory concentration: 15700 nM
Compound 4: the middle estimate sits 1.6-fold (0.20 log units) below what was measured; measured number inside the range.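

In this assay the larger dibutylamino group on the shorter chain cannot be told apart from the diethylamino arrangement, with a 1.2-fold higher number from compound 3 to compound 4 (0.07 log units; within the scatter) as the step. A second amino compound also reads stronger than the compounds without an amino group, with an at least 3.1-fold lower number from compound 2 to compound 4 (0.50 log units; beyond the scatter) and an at least 3.1-fold lower number from compound 1 to compound 4 (0.50 log units; beyond the scatter) as its steps. Compound 1 and compound 2 each stand only at a limit of the assay: the limit of > 50000 nM in this assay, at which 2 of the 4 values shown sit.

The compounds shown leave open how a piperidine, a primary amine or a carboxylic acid would read in place of dibutylamino. They also leave open whether a chain shorter than propyl would hold this level.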